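The compounds below may be only part of what the source reports. "The series", "measured", "known", "first", "only" and "open" are said of these compounds alone.

Measured compounds in an assay on cell membranes for displacement of a labelled ligand from Neuronal acetylcholine receptor; alpha4/beta2 (Rattus norvegicus); on this read-out lower numbers stand for stronger inhibition and higher numbers for weaker inhibition:
- compound 1 `O=[N+]([O-])c1ccc(Nc2ccc(N3CC4CC(C3)N4)cn2)cc1` gives 1.76 nM
- compound 2 `Fc1ccc(Nc2ccc(N3CC4CC(C3)N4)cn2)cc1` gives 2.38 nM

Going by the values given here, compound 2 holds the higher of the two numbers so far, but the gap to compound 1 is small: a 1.4-fold higher number from compound 1 to compound 2 (0.13 log units; within the scatter). On this read-out the two compounds therefore cannot be told apart.

Compound 3 `COc1ccc(Nc2ccc(N3CC4CC(C3)N4)cn2)cc1` is the next step from compound 2. The change is methoxy in place of fluoro on an aromatic carbon. Among the compounds with values here, only one measured step bears on a change at this aromatic carbon, the exchange of nitro for fluoro, and that step stayed within the scatter. With the substituent at this position shown to matter little between compound 1 and compound 2, a small step is expected here as well, most likely a 1.3-fold higher number from compound 2 to compound 3 (0.10 log units; within the scatter), with no clear direction beyond the scatter.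

Compound 3 is therefore estimated at 3 nM in this assay, within a range from 1 nM to 10 nM.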

Compound 3, inhibition constant: 7.3 nM
Compound 3: middle estimate off by 2.4-fold (0.39 log units), on the low side; low and high end bracket the measured number.
By their numbers in this assay, from the lowest: compounds 1 and 2 (each within the scatter of the next); then compound 3.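

In this assay, going by these compounds alone, the group on this aromatic carbon turns out to make a difference: methoxy in place of fluoro gives a 3.1-fold higher number from compound 2 to compound 3 (0.49 log units; beyond the scatter) and methoxy in place of nitro gives a 4.1-fold higher number from compound 1 to compound 3 (0.62 log units; beyond the scatter) as the first steps here to lie beyond the scatter. Nitro and fluoro could not be told apart, so that earlier result does not extend to every group at this carbon, although both new steps are only modest. Nothing available here explains why methoxy goes with the higher number.

Going by these compounds, what a hydroxyl, a longer ethoxy chain or an amine on this carbon would give stays open. Also open, on these data alone, is whether the higher number belongs to methoxy alone or to other groups attached through oxygen as well.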